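Adding a Methyl Group to Compound 3

This account rests on a few compounds, and the source may have more. Where it says the series, first, only, none or still open, it means among the compounds named here.

Compound 1 `CCCCc1nc2ccccc2n1Cc1cc(Cl)c(O)c(Cl)c1`, compound 2 `CCCc1nc2cccnc2n1Cc1cc(Cl)c(O)c(Cl)c1` and compound 3 `Oc1c(Cl)cc(Cn2c(C3CC3)nc3cccnc32)cc1Cl` share one core and were tested in a functional assay (aorta) with Oryctolagus cuniculus as the target; on this read-out lower numbers stand for tighter binding and higher numbers for weaker binding. Compound 1 gives 63.1 nM, compound 2 gives 31.6 nM, and compound 3 gives 20 nM, the lowest of the three numbers; its gap to compound 2 is within the scatter, while its gap to compound 1 lies beyond it. Within the data shown here, the only step between close neighbours, a 1.6-fold lower number from compound 2 to compound 3 (0.20 log units; within the scatter), was small. Compound 4 `Cc1ccnc2c1nc(C1CC1)n2Cc1cc(Cl)c(O)c(Cl)c1` differs from compound 3 by methyl in place of hydrogen on an aromatic carbon. Among the measured compounds shown here, no measured step tests this change, and the one step known in this assay stayed within the scatter, so no step beyond the scatter is expected in either direction. Compound 4 is therefore estimated at 20 nM, between 8 nM and 50 nM. The expected step is no change at the digits printed from compound 3 to compound 4 (within the scatter).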

Compound 4, dissociation constant: 2 nM
The estimate for compound 4 lay 10-fold (1.00 log units) above the measured number; measured number below the stated range.
By their numbers in this assay, from the lowest: compound 4; then compounds 3, 2 and 1 (each within the scatter of the next, the first and the last beyond it).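

Methyl in place of hydrogen on an aromatic carbon, opposite the ring nitrogen, gives in this assay a 10-fold lower number from compound 3 to compound 4 (1.00 log units; beyond the scatter), whereas the one earlier step between close neighbours, a 1.6-fold lower number from compound 2 to compound 3 (0.20 log units; within the scatter), stayed within the scatter. This position therefore responds to the addition of a single carbon, and this change moves the number further than the exchange of propyl for cyclopropyl did. No measured evidence bears on this result.

The compounds shown leave open whether ethyl, methoxy or an amine at this position would give a similar step. They also leave open whether methyl here would give the same step with propyl in place of cyclopropyl.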